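The source may report more compounds than this note shows. Statements on the series, on what has been measured and on what is new or still open speak of the compounds shown alone.

Measured in a functional assay on DU-145 cells (Homo sapiens) for inhibition, read by trypan blue exclusion, with a stated time of 72 h; on this read-out lower numbers stand for stronger inhibition and higher numbers for weaker inhibition:
- compound 1 `Cn1c(=O)c(S(=O)(=O)c2ccc(F)cc2F)cc2cnc(Nc3ccc4c(c3)CC(=O)N4)nc21`: 100000 nM
- compound 2 `Cn1ccc2cc(Nc3ncc4cc(S(=O)(=O)c5ccc(F)cc5F)c(=O)n(C)c4n3)ccc21`: 750 nM
- compound 3 `Cn1c(=O)c(S(=O)(=O)c2ccccc2)cc2cnc(Nc3ccc4cc[nH]c4c3)nc21`: 10000 nM

Compound 3 holds the second highest of the three values, with compound 1 above it and compound 2 below it.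

The next change leads to compound 4 `Cn1c(=O)c(S(=O)(=O)c2ccc(F)cc2F)cc2cnc(Nc3ccc4cc[nH]c4c3)nc21`: 2,4-difluorophenyl in place of phenyl on a sulfonyl sulfur.

Among the compounds with values here, no measured step isolates this change. The only one, a 130-fold lower number from compound 1 to compound 2 (2.12 log units; beyond the scatter), is large but lies on a nitrogen on an aromatic ring, and both of its compounds carry the 2,4-difluorophenyl group. Within the data shown here, it shows only that a change elsewhere can move this read-out strongly. The direction rests on weaker evidence: compound 2, which carries 2,4-difluorophenyl, gives 750 nM, while compound 3, which carries phenyl, gives 10000 nM. These two compounds also differ in other places, so the comparison is loose.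

A moderate move to a lower number is expected, estimated as a 5.0-fold lower number from compound 3 to compound 4 (0.70 log units; beyond the scatter), and no change beyond the scatter remains possible. For compound 4 the estimated value is 2000 nM, with an expected range of 350 nM to 10000 nM.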

Compound 4, half-maximal inhibitory concentration: 5000 nM
Beside the measured number, compound 4's estimate is 2.5-fold (0.40 log units) below it; the range from low to high includes it.
By their numbers in this assay, from the lowest: compound 2; then compounds 4 and 3 (each within the scatter of the next); then compound 1.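

In this assay the change on the sulfonyl sulfur gives a 2.0-fold lower number from compound 3 to compound 4 (0.30 log units; within the scatter), so with 1H-indol-6-yl held fixed, this place does not separate 2,4-difluorophenyl from phenyl. With 2,4-difluorophenyl held fixed, the larger moves come from the group on a nitrogen on an aromatic ring: a 6.7-fold higher number from compound 2 to compound 4 (0.82 log units; beyond the scatter) for 1H-indol-6-yl in place of 1-methyl-1H-indol-5-yl, and a 20-fold lower number from compound 1 to compound 4 (1.30 log units; beyond the scatter) for 1H-indol-6-yl in place of the group with the five-membered non-aromatic ring. No supporting data bear on these results.

Within the data shown here, only two aryl groups appear on the sulfonyl sulfur, so a pyridine ring or a short alkyl chain there remains open. Also open, from the compounds shown here alone, is how phenyl compares with 2,4-difluorophenyl when 1-methyl-1H-indol-5-yl is the group on the nitrogen.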